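The compounds below may be only part of what the source reports. "The series", "measured", "known", "first", "only" and "open" are said of these compounds alone.

In an ADME assay on S9 fraction from liver (Homo sapiens) for metabolic stability, read by LC-MS, using NADPH, with stated times of 5 min and 60 min, tested at 5 uM (on this read-out lower numbers stand for a less stable compound and higher numbers for a more stable compound), compound 1 `COc1cc(C2CN(C(=O)c3cc(OCCCC(C)(C)C(=O)O)ccn3)C2)ccc1OCc1ccc(C2CC2)cc1` gives 81%, and compound 2 `COc1cc(C2CN(C(=O)c3cc(COC[C@H](O)CO)ccn3)C2)ccc1OCc1ccc(C2CC2)cc1` stands lower at 62%. Compound 3 `COc1cc(C2CN(C(=O)c3cc(COCC(CO)CO)ccn3)C2)ccc1OCc1ccc(C2CC2)cc1` differs from compound 2 only within the diol-bearing chain: 2-hydroxy-1-(hydroxymethyl)ethyl in place of 1,2-dihydroxyethyl on a saturated chain carbon bound to an oxygen on a saturated carbon. Among the compounds with values here, the one measured step, a number 19 percentage points lower from compound 1 to compound 2 (beyond the scatter), replaced a whole side chain, so it is a much larger edit and offers only loose guidance here. Within the data shown here, no measured step tests this smaller rearrangement, so no direction can be argued from the data. The expected change is a number 2 percentage points lower from compound 2 to compound 3 (within the scatter), which would stay within the usual scatter. Compound 3 is estimated at 60%, with an expected range from 45% to 75%.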

Compound 3, percent of the compound remaining: 55%
Compound 3: the middle estimate sits 5 percentage points above what was measured; the range from low to high includes it.
By their numbers in this assay, from the lowest: compounds 3 and 2 (each within the scatter of the next); then compound 1.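

In this assay, changing the 1,2-dihydroxyethyl group to 2-hydroxy-1-(hydroxymethyl)ethyl on this saturated chain carbon gives a number 7 percentage points lower from compound 2 to compound 3 (within the scatter), so this rearrangement of the chain has no effect that can be told from the scatter. The larger replacement of the (4-carboxy-4-methylpentyl)oxy group gives a number 26 percentage points lower from compound 1 to compound 3 (beyond the scatter), so this second diol-bearing chain also stays clearly short of compound 1.

From the compounds shown here alone, whether an amine or a longer chain at this place would come closer to compound 1 remains open. No supporting data explain either step.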